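Nitro in place of fluoro: compound 2 to compound 4

The source may hold more compounds than are shown below. What is called first, only, known or untested is meant among the compounds shown, and "the series" means these compounds.

Measured in a functional assay on HepG2 cells (Homo sapiens) for cytotoxicity, read by MTT assay, with a stated time of 24 h; a lower number here means a stronger inhibitor, a higher number a weaker inhibitor:
- compound 1 `Cc1ccc(Cc2cn3cc(Cl)ccc3nc2=O)cc1`: > 1000000 nM (a limit, not a number)
- compound 2 `O=c1nc2ccc(Cl)cn2cc1Cc1ccc(F)cc1`: > 1000000 nM (a limit, not a number)
- compound 3 `O=c1nc2ccc(Cl)cn2cc1Cc1ccc(Oc2nc(Cl)c(Cl)cc2Cl)cc1`: 992000 nM

Compound 2 stands only at a limit, > 1000000 nM, and its true position in this assay cannot be read. The same holds for compound 1, whose > 1000000 nM is also a limit. Going by the values given here, compound 3 gives 992000 nM, the only actual number. The data so far amount to the limit of > 1000000 nM in this assay, at which 2 of the 3 values shown sit.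

Compound 4 `O=c1nc2ccc(Cl)cn2cc1Cc1ccc([N+](=O)[O-])cc1` carries nitro in place of fluoro on an aromatic carbon, on a six-membered aromatic ring of carbon only. Among the compounds with values here, the only measured step that bears on this change swaps fluoro in place of methyl on an aromatic carbon, and it provides no size to carry over. No step beyond the scatter is expected in this assay, in either direction, because a step that the two limits leave unreadable from compound 1 to compound 2 is all that has been measured. The expected step is a number no higher from compound 2 to compound 4 (the limit leaves the size open).

A reading of compound 4 as another limit would not be surprising. Compound 4 is estimated at 1000000 nM, with an expected range of 500000 nM to 2000000 nM.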

Compound 4, half-maximal inhibitory concentration: > 1000000 nM
Compound 4 gave a limit, no number (the forecaster's own chance of this, stated with the estimate: 65%); the middle value sits exactly at the limit.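

In this assay compound 4 gives > 1000000 nM, a limit and not a number. No step can be read between compound 4 and compound 1 or compound 2, as those values are limits too. The compounds shown leave open whether methyl, fluoro and nitro on the aromatic carbon differ at all in this assay.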